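Swapping hydroxymethyl for ethoxycarbonyl in an inactive series

A few compounds are considered here, and "the series" means these few. Any claim that something is new, unique, unknown or untested is made for them only; others in the source may bear on it.

Measured so far in a functional assay on K562 cells (Homo sapiens) for cytotoxicity, read by MTT assay, with a stated time of 48 h; on this read-out higher numbers stand for weaker inhibition and lower numbers for stronger inhibition (each value is a limit of the assay, not a number):
- compound 1 `CCOC(=O)[C@@]1(C(=O)NCc2ccc(C)cc2)C[C@H]1c1cc(OC)c(OC)c(OC)c1` gives > 100000 nM as a limit
- compound 2 `COc1cc([C@H]2C[C@]2(CO)C(=O)NCc2ccc(C)cc2)cc(OC)c1OC` gives > 100000 nM as a limit
- compound 3 `CCOC(=O)C1(C(=O)NCc2ccc(C)cc2)CC1c1cc(OC)c(OC)c(OC)c1` gives > 100000 nM; > 100000 nM (2 entries) as a limit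

Compound 2 therefore has no exact value, and in this assay it stands at > 100000 nM as a limit only. Within the data shown here, with limits alone, no measured step exists to show how much any structural change matters.

The next compound to be measured is compound 4 `CCOC(=O)[C@]1(C(=O)NCc2ccc(C)cc2)C[C@@H]1c1cc(OC)c(OC)c(OC)c1`, which has ethoxycarbonyl in place of hydroxymethyl on a saturated ring carbon of the three-membered ring: ethoxycarbonyl in place of hydroxymethyl on a saturated ring carbon. Ethoxycarbonyl is not new to this set. Compound 1 carries it and gives > 100000 nM as a limit. Compound 3 also carries it and gives > 100000 nM; > 100000 nM (2 entries) as a limit. No change beyond the scatter is therefore expected in this assay, and the most likely result is another limit rather than a number. The expected size of the change is a number no higher from compound 2 to compound 4 (the limit leaves the size open) in this estimate. For compound 4 the estimated value is 100000 nM, with an expected range from 50000 nM to 200000 nM.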

Compound 4, half-maximal inhibitory concentration: 20400 nM
Estimate against measurement, compound 4: 4.9-fold (0.69 log units) above; the measured number lies below the stated range.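

In this assay, among these compounds, compound 4 provides the first real number in this set, and it shows that the group on this saturated ring carbon of the three-membered ring can shift the read-out: ethoxycarbonyl in place of hydroxymethyl gives an at least 4.9-fold lower number from compound 2 to compound 4 (0.69 log units; beyond the scatter). Ethoxycarbonyl alone does not secure this result, since configuration matters too, as an at least 4.9-fold lower number from compound 1 to compound 4 (0.69 log units; beyond the scatter) shows, and both steps are open-ended in size, as each starts from a limit of the assay rather than a number. The contrast between these two mirror images is especially clean, as it involves no change of atoms or bonds: the fact that compounds 1 and 4 differ only in the configuration as drawn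

As far as these compounds go, compound 3 gives > 100000 nM; > 100000 nM (2 entries), which is a limit, and what its drawing means for the comparison stays open: the fact that one of compounds 3 and 4 is drawn with a defined configuration and the other without, at the place where they differ Also open are whether a carboxylic acid, an aminomethyl group or a longer ester chain such as butoxycarbonyl on the same ring carbon would give a lower number than ethoxycarbonyl, and why the configuration of compound 4 gives a measurable value at all.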